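This account rests on a few compounds, and the source may have more. Where it says the series, first, only, none or still open, it means among the compounds named here.

Measured so far in an ADME assay on HEp-2 cells (Homo sapiens) for cytotoxicity, read by CCK-8 assay, with a stated time of 6 days; on this read-out higher numbers stand for lower toxicity in this test and lower numbers for higher toxicity in this test:
compound 1 `O=c1n(Cc2nc3cc(Cl)ccn3c2CCCCO)c2cnccc2n1C1CC1`, compound 1 gives > 100000 nM, a limit of the test
compound 2 `O=c1n(Cc2cn3ccc(Cl)cc3n2)c2cnccc2n1C1CC1`, compound 2 gives 22300 nM
compound 3 `O=C(O)c1c(Cn2c(=O)n(C3CC3)c3ccncc32)nc2cc(Cl)ccn12`, compound 3 gives > 100000 nM, a limit of the test

Compound 3 therefore stands at the top of what this assay can report: its value is a limit, not a number. Compound 1 sits at the same limit, so two of the three values shown are limits, as summarised in the limit of > 100000 nM in this assay, at which 2 of the 3 values shown sit. Only compound 2 gives a number.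

Compound 4 `O=C(O)/C=C/c1c(Cn2c(=O)n(C3CC3)c3ccncc32)nc2cc(Cl)ccn12` differs from compound 3 by 2-carboxyethenyl in place of carboxy on an aromatic carbon. Going by the values given here, two measured steps touch this position. The step of an at least 4.4-fold higher number from compound 2 to compound 3 (0.65 log units; beyond the scatter) shows that putting carboxy at this carbon moved the value out of the readable range. The step that the two limits leave unreadable from compound 1 to compound 3 cannot be sized because both ends sit at the limit of > 100000 nM in this assay, at which 2 of the 3 values shown sit.

Compound 4 keeps an acid at the same position, now on a 2-carboxyethenyl chain rather than directly attached. Among the compounds with values here, with compound 3 at the limit and no measured step pointing downward, compound 4 is expected to remain at or near the limit in this assay. The estimate for compound 4 is 100000 nM, with a range of 30000 nM to 300000 nM. This expected step, a number no higher from compound 3 to compound 4 (the limit leaves the size open), is no change beyond the scatter, and most likely the test will again report only a limit.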

Compound 4, half-maximal cytotoxic concentration: > 100000 nM
Compound 4: a limit, no number; the forecaster's own chance of this, stated with the estimate: 70%; the middle value sits exactly at the limit.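

In this assay compound 4 gives > 100000 nM, a limit of the test and not a number. Extending carboxy to 2-carboxyethenyl leaves the result at that limit, and against the hydrogen on this aromatic carbon the change is an at least 4.4-fold higher number from compound 2 to compound 4 (0.65 log units; beyond the scatter), so three different groups at this carbon (4-hydroxybutyl, carboxy and 2-carboxyethenyl) now share this outcome, while compound 2, with hydrogen, is the only compound here to give a number. The steps among compound 1, compound 3 and compound 4 cannot be read, and the top of the range now holds most of the series: the limit of > 100000 nM in this assay, at which 3 of the 4 values shown sit.

Any ranking among these three compounds therefore remains open, as does whether the acid group contributes anything beyond what the neutral 4-hydroxybutyl chain of compound 1 already gives. On these data alone, it is also open whether a small group such as methyl, or an amine on a short chain, at this carbon would stay at the limit or give a number closer to that of compound 2.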